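The source may hold more compounds than are shown below. What is called first, only, known or untested is meant among the compounds shown, and "the series" means these compounds.

Notes on the hydrazone series. For the measured compounds named here, the three measured members share one core and differ only in the group on the carbon with a double bond to nitrogen. In an assay on isolated protein for inhibition of Amine oxidase [flavin-containing] B (Homo sapiens), read by spectrophotometry (a lower number here means a stronger inhibitor, a higher number a weaker inhibitor), compound 1 `COc1ccc(/C=N/Nc2nc3ccccc3nc2Cc2ccccc2)cc1OC` gives 460000 nM. Going by the values given here, compound 3 `CN(C)c1ccc(/C=N/Nc2nc3ccccc3nc2Cc2ccccc2)cc1` gives 880000 nM in this assay, and the single one-place step, a 1.9-fold higher number from compound 1 to compound 3 (0.28 log units; within the scatter), stays within the scatter. Compound 2 `C/C(=N\Nc1nc2ccccc2nc1Cc1ccccc1)c1ccccc1` gives 980000 nM, the highest of the three numbers: next to it sits compound 3, within the scatter, while compound 1 lies beyond the scatter on the lower side.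

The step to compound 4 `C/C(=N\Nc1nc2ccccc2nc1Cc1ccccc1)c1cccs1` is thiophen-2-yl in place of phenyl on a carbon with a double bond to nitrogen. Among the compounds with values here, no measured pair exchanges a phenyl for a five-membered aromatic ring, so nothing bears on this step directly; the only comparable change, an exchange of aryl groups on the same carbon between compound 1 and compound 3, was within the scatter. On that basis the step from compound 2 to compound 4 is expected to fall within the scatter, with no direction claimed, which in this assay is a 1.1-fold lower number from compound 2 to compound 4 (0.04 log units; within the scatter). For compound 4 the value in this assay is therefore estimated at 900000 nM, with a range from 400000 nM to 2000000 nM.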

Compound 4, half-maximal inhibitory concentration: 850000 nM
Beside the measured number, compound 4's estimate is 1.1-fold (0.02 log units) above it; the range from low to high includes it.
By their numbers in this assay, from the lowest: compounds 1, 4, 3 and 2 (each within the scatter of the next, the first and the last beyond it).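

In this assay, the exchange of phenyl for thiophen-2-yl on a carbon with a double bond to nitrogen gives a 1.2-fold lower number from compound 2 to compound 4 (0.06 log units; within the scatter). For the compounds shown here, this is the first one-place step to replace a six-membered aromatic ring of carbon only with a five-membered aromatic ring with 1 hetero atom, and at this place neither that exchange nor the move from 0 hydrogen-bond acceptors to 1 hydrogen-bond acceptor in the group carries the number beyond the scatter. Nothing measured here explains the size of this step.

The compounds shown leave open whether a five-membered aromatic ring with a different hetero atom, such as furan-2-yl, or an aromatic ring carrying an amine or a carboxylic acid, would give a step beyond the scatter at this place. Going by these compounds alone, also open is what a longer chain would do in place of the saturated chain carbon on the same carbon with a double bond to nitrogen, since the one-place steps so far concern only the aromatic group.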